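A few compounds are considered here, and "the series" means these few. Any claim that something is new, unique, unknown or untested is made for them only; others in the source may bear on it.

Measured so far in a physicochemical assay for lipophilicity, at pH 7.4; on this read-out higher numbers stand for higher lipophilicity and lower numbers for lower lipophilicity
- compound 1 (`Oc1c(-c2nnc(Cc3ccc(Cl)cc3)[nH]2)ncc2cccnc12`), result (4.1)
- compound 2 (`Oc1c(-c2nc(C(O)c3ccccc3)n[nH]2)ncc2cccnc12`), result ("not determined" (no result reported))

Compound 2 has no number: no result was reported, so its place in the series cannot be read from the data, and compound 1 remains the only measured point. Compound 3 (`Cc1n[nH]c(-c2ncc3cccnc3c2O)n1`) awaits measurement. It differs from compound 2 by methyl in place of hydroxy(phenyl)methyl on an aromatic carbon. No measured step sizes this change in this assay, so the expectation is tentative: a large downward step from compound 2, beyond the usual scatter, with the aromatic ring of the departing group gone. Within the data shown here, the only anchor is compound 1 (4.1), and compound 3 is expected to fall well under it. The estimated value for compound 3 is 1.7, with an expected range from 0.9 to 2.5.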

Compound 3, distribution coefficient: 0.73
Estimate against measurement, compound 3: 0.97 log units above; the whole stated range lies above it.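

In this assay compound 3 gives 0.73, but compound 2 carries no number, so no step can be read between compound 2 and compound 3. On these data alone, what replacing hydroxy(phenyl)methyl with methyl is worth on this read-out stays open. No evidence bears on this result.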